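Swapping the aryl group on the amine nitrogen

This account rests on a few compounds, and the source may have more. Where it says the series, first, only, none or still open, it means among the compounds named here.

Measured compounds:
compound 1, `CC1=NN(C(=O)c2cc3ccccc3oc2=O)C(=O)C1CNc1ccc(S(N)(=O)=O)cc1`, 77.9%
compound 2, `CC1=NN(C(=O)c2cc3ccccc3oc2=O)C(=O)C1CNc1ccc(O)c(C(=O)O)c1`, 50.9%

Of the compounds shown here, two sharing one core have been tested in a functional assay on the whole organism for inhibition, with Rattus norvegicus as the target, read by paw edema, with stated times of 1 h and 6 h, at a dose of 0.03 mg/kg by the oral route; a higher number here means more inhibition at the dose given (going by the name of the read-out), a lower number less inhibition. Compound 1 gives 77.9% in this assay, while compound 2 gives 50.9%. Among the compounds with values here, compound 2 thus stands at the lower of the two numbers; the single step between them, a number 27 percentage points lower from compound 1 to compound 2 (beyond the scatter), shows that the aryl group on the amine nitrogen changes the read-out by a modest but real amount.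

Compound 3, `CC1=NN(C(=O)c2cc3ccccc3oc2=O)C(=O)C1CNc1ccc([N+](=O)[O-])cc1`, is not yet measured. It differs from compound 2 in one place: 4-nitrophenyl in place of 3-carboxy-4-hydroxyphenyl on an amine nitrogen. Within the data shown here, no measured step bears directly on a nitrophenyl group here; the only guide is that the earlier step, a number 27 percentage points lower from compound 1 to compound 2 (beyond the scatter), was modest in size. An upward step of similar or smaller size is expected in this assay for compound 3, since both measured numbers lie in the middle to upper part of the scale, but the direction is uncertain.

Compound 3 is estimated at 63%, with a range from 42% to 84%, corresponding to an expected step of a number 12.1 percentage points higher from compound 2 to compound 3 (beyond the scatter).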

Compound 3, a percentage reported as inhibition, in the whole organism at one dose (the size of the read-out at that dose, not a potency): 72%
Compound 3: middle estimate off by 9 percentage points, on the low side, and the stated range covers the measured number.
By their numbers in this assay, from the lowest: compound 2; then compounds 3 and 1 (each within the scatter of the next).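

Putting 4-nitrophenyl in place of 3-carboxy-4-hydroxyphenyl on the amine nitrogen gives a number 21.1 percentage points higher from compound 2 to compound 3 (beyond the scatter) in this assay, so the lower number of compound 2 is not shared by every change of aryl group at this position. Nitro in place of sulfamoyl on the aromatic carbon gives a number 5.9 percentage points lower from compound 1 to compound 3 (within the scatter), which means that 4-nitrophenyl and 4-sulfamoylphenyl cannot be told apart in this read-out at this single dose, while 3-carboxy-4-hydroxyphenyl stands apart from both among these three compounds. Nothing available explains why these aryl groups fall as they do.

The compounds shown leave open whether the carboxylic acid or the hydroxyl group of compound 2 goes with its lower number, which a 3-carboxyphenyl or a 4-hydroxyphenyl group on the same amine nitrogen would help to separate. They also leave open whether a plain phenyl, a 4-aminophenyl or a 4-methoxyphenyl group would stay level with compound 1 and compound 3 or fall nearer to compound 2.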